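This account rests on a few compounds, and the source may have more. Where it says the series, first, only, none or still open, it means among the compounds named here.

Compound 1 `COC(=O)[C@@]1(C)CCC=C2[C@@H]1CC[C@@H](C)[C@]2(C)Cc1c(C)[nH]c2ccc(Br)cc12` gives 11000 nM in a functional assay on HeLa cells (Homo sapiens) for inhibition, read by sulforhodamine B assay, with a stated time of 48 h; a lower number here means a stronger inhibitor of growth, a higher number a weaker inhibitor of growth. Compound 2 `COC(=O)[C@@]1(C)CCC=C2[C@@H]1CC[C@@H](C)[C@]2(C)Cc1c(C)[nH]c2ccc(Cl)cc12` gives 12000 nM in this assay. Compound 3 `COC(=O)[C@@]1(C)CCC=C2[C@@H]1CC[C@@H](C)[C@]2(C)Cc1c(C)[nH]c2c(Br)cccc12` gives 22000 nM in this assay.

From compound 1 to compound 2 the change is chloro in place of bromo on an aromatic carbon, and the step it made in this assay was a 1.1-fold higher number from compound 1 to compound 2 (0.04 log units; within the scatter). Compound 3 shares the atoms of compound 1 joined differently; the difference between the two cores is not broken down here. Compound 4 `COC(=O)[C@@]1(C)CCC=C2[C@@H]1CC[C@@H](C)[C@]2(C)Cc1c(C)[nH]c2c(Cl)cccc12` is reached from compound 3 by chloro in place of bromo on an aromatic carbon, the same kind of change as that from compound 1 to compound 2, though here the place is ortho to a fused ring and meta to a fused ring rather than meta and para to a fused ring. Because a 1.1-fold higher number from compound 1 to compound 2 (0.04 log units; within the scatter) was within the scatter, the step from compound 3 to compound 4 is expected to be about a 1.1-fold higher number from compound 3 to compound 4 (0.04 log units; within the scatter). Compound 4 is therefore estimated at 24000 nM, expected to fall between 12000 nM and 48000 nM.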

Compound 4, concentration for 50% growth inhibition: 17000 nM
Compound 4: middle estimate off by 1.4-fold (0.15 log units), on the high side; the measured number falls inside the stated range.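

In this assay, chloro in place of bromo gave a 1.3-fold lower number from compound 3 to compound 4 (0.11 log units; within the scatter). Set beside the same change on the other core, the two steps do not differ: the same change on two cores in this assay, a 1.1-fold higher number (0.04 log units; within the scatter) from compound 1 to compound 2 and a 1.3-fold lower number (0.11 log units; within the scatter) from compound 3 to compound 4, 1.4-fold (0.15 log units) apart, within the scatter of two such steps. This shows that, on these two cores, exchanging the two halogens left the number within the scatter each time, but it does not show that the change would behave the same way on a further core or at another place on the ring, and it gives no cause for the result.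

The compounds shown leave open what a nitrile, a methoxy group or an amine on that ring would do in place of the halogen. They also leave open how a carboxylic acid or an amide in place of the methyl ester would read.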